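Swapping chloro for dimethylamino in a thioenone series

This account rests on a few compounds, and the source may have more. Where it says the series, first, only, none or still open, it means among the compounds named here.

Compound 2 `O=C(/C(=C\c1ccc(Cl)cc1)SCc1ccc(F)cc1)c1ccc(Cl)cc1` is tested in a functional assay on DU-145 cells (Homo sapiens) for inhibition, read by trypan blue exclusion, with a stated time of 96 h (a lower number here means a stronger inhibitor of growth, a higher number a weaker inhibitor of growth), where compound 2 gives 10000 nM. This puts it level with compound 1 `Cc1ccc(S/C(=C/c2ccc(Cl)cc2)C(=O)c2ccc(Cl)cc2)cc1`, which gives 10000 nM, the two together being the highest of the three numbers, while compound 3 `O=C(/C(=C\c1ccc(Cl)cc1)Sc1ccc(Cl)cc1)c1ccc(Cl)cc1` gives 1000 nM, a step of a 10-fold lower number from compound 2 to compound 3 (1.00 log units; beyond the scatter). Compound 4 `CN(C)c1ccc(/C=C(/SCc2ccc(F)cc2)C(=O)c2ccc(Cl)cc2)cc1` differs from compound 2 by dimethylamino in place of chloro on an aromatic carbon. Among the compounds with values here, none of the measured steps touches this part of the shared core: no change at the digits printed from compound 1 to compound 2 (within the scatter) and a 10-fold lower number from compound 2 to compound 3 (1.00 log units; beyond the scatter) alter the group on the sulfur, and a 10-fold lower number from compound 1 to compound 3 (1.00 log units; beyond the scatter) alters the 4-chlorophenyl on a sulfur. With no direct guide, the expectation for compound 4 is a step of no change at the digits printed from compound 2 to compound 4 (within the scatter), within the scatter. Compound 4 is therefore estimated at 10000 nM, with a range from 3000 nM to 30000 nM.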

Compound 4, concentration for 50% growth inhibition: 50000 nM
For compound 4 the middle estimate is 5.0-fold (0.70 log units) below the measured one, outside the stated range (above it).
By their numbers in this assay, from the lowest: compound 3; then compounds 1 and 2 (each within the scatter of the next); then compound 4.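

Putting 4-(dimethylamino)phenyl in place of 4-chlorophenyl gives a 5.0-fold higher number from compound 2 to compound 4 (0.70 log units; beyond the scatter) in this assay, and a higher number here means a weaker inhibitor of growth. Within the data shown here, this shows that the part of the shared core left untouched by the earlier steps also matters, and that this change weakens growth inhibition. Nothing measured here explains the shift.

Open, on these data alone, is how a methoxy group or a simple amino group would fare at this position. Also open, as far as these compounds go, is whether the same change would weaken compound 3, which carries a different group on the sulfur.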